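A few compounds are considered here, and "the series" means these few. Any claim that something is new, unique, unknown or untested is made for them only; others in the source may bear on it.

For the measured compounds named here, compound 3 `COc1ccc(-c2cc3nccc(-c4cc(OC)c(OC)c(OC)c4)n3n2)cc1` gives 125 nM in a functional assay on MCF7 cells (Homo sapiens) for inhibition, read by CCK-8 assay, with a stated time of 48 h (a higher number here means a weaker inhibitor, a lower number a stronger inhibitor), the second highest of the three numbers known; compound 2 `COc1cc(-c2ccnc3cc(-c4ccc5cnn(C)c5c4)nn23)cc(OC)c1OC` is nearest with 279 nM, and compound 1 `COc1cc(-c2ccnc3cc(-c4ccc(N(C)C)cc4)nn23)cc(OC)c1OC` is furthest with 44 nM. Compound 4 `COc1cc(-c2ccnc3cc(-c4ccc5c(ccn5C)c4)nn23)cc(OC)c1OC` is not yet measured; it differs from compound 3 by 1-methyl-1H-indol-5-yl in place of 4-methoxyphenyl on an aromatic carbon. The step bearing most directly on this is a 2.2-fold lower number from compound 2 to compound 3 (0.35 log units; beyond the scatter), where the 1-methyl-1H-indazol-6-yl group went with the higher number; a 6.3-fold higher number from compound 1 to compound 2 (0.80 log units; beyond the scatter) points the same way, as does a 2.8-fold higher number from compound 1 to compound 3 (0.45 log units; beyond the scatter) to a lesser degree. A modest upward step is therefore expected for compound 4, namely a 1.8-fold higher number from compound 3 to compound 4 (0.25 log units; within the scatter). The estimate for compound 4 is 220 nM, with a range from 90 nM to 550 nM.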

Compound 4, half-maximal inhibitory concentration: 3 nM
Compound 4: middle estimate off by 73-fold (1.87 log units), on the high side; measured number below the stated range.
By their numbers in this assay, from the lowest: compound 4; then compound 1; then compound 3; then compound 2.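

In this assay, for the compounds shown here, the aromatic carbon of the five-membered ring with 2 nitrogen proves far more sensitive than the earlier compounds showed, with a 42-fold lower number from compound 3 to compound 4 (1.62 log units; beyond the scatter) and a 15-fold lower number from compound 1 to compound 4 (1.17 log units; beyond the scatter) as 1-methyl-1H-indol-5-yl replaces each substituted phenyl group. Having two fused rings does not by itself settle the outcome, since replacing 1-methyl-1H-indazol-6-yl gives a 93-fold lower number from compound 2 to compound 4 (1.97 log units; beyond the scatter) here. Nothing available explains these gaps. Still open, on these data alone, is whether the gain survives on 1H-indol-5-yl without the methyl, or with 1-methyl-1H-indol-6-yl, which would separate the methyl from the attachment point.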